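Chloromethylbenzyl purines: removing the second chloro

The compounds below may be only part of what the source reports. "The series", "measured", "known", "first", "only" and "open" are said of these compounds alone.

Measured so far:
compound 1 `ClCc1ccc(Cn2cnc3c(Cl)ncnc32)cc1` gives 1120 nM
compound 2 `ClCc1ccccc1Cn1cnc2c(Cl)nc(Cl)nc21` gives 190 nM

In a functional assay on HCT-116 cells (Homo sapiens) for cytotoxicity, read by sulforhodamine B assay, with a stated time of 48 h (on this read-out higher numbers stand for weaker inhibition of growth and lower numbers for stronger inhibition of growth), compound 2 stands lowest of the two numbers; compound 1 gives a number that lies beyond the scatter above it. Compound 3 `ClCc1ccccc1Cn1cnc2c(Cl)ncnc21` differs from compound 2 by hydrogen in place of chloro on an aromatic carbon, that is, the chloro between two ring nitrogen atoms of the core is replaced by hydrogen. Among the measured compounds shown here, no measured pair shows this step. A moderate rise in the number is expected, with the expected step from compound 2 to compound 3 being a 2.6-fold higher number from compound 2 to compound 3 (0.42 log units; beyond the scatter). Compound 3 is therefore estimated at 500 nM, within a range from 180 nM to 1400 nM.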

Compound 3, concentration for 50% growth inhibition: 1900 nM
For compound 3 the middle estimate is 3.8-fold (0.58 log units) below the measured one; the measured number lies above the stated range.
By their numbers in this assay, from the lowest: compound 2; then compounds 1 and 3 (each within the scatter of the next).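

In this assay, among the compounds shown here, the first matched step shows that the chloro between two ring nitrogen atoms of the core matters: replacing it by hydrogen gives a 10-fold higher number from compound 2 to compound 3 (1.00 log units; beyond the scatter) and takes away much of the growth inhibition seen with compound 2. No measurement here bears on why the number rises. From the compounds shown here alone, whether an amine or a methoxy group at this position would keep the number of compound 2 remains open. Also open, going by these compounds, is what a methyl group in place of the chloromethyl group would do.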